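Iodo in place of ethoxy: compound 2 to compound 4

The compounds below may be only part of what the source reports. "The series", "measured", "known", "first", "only" and "open" are said of these compounds alone.

Of the compounds shown here, three on the shared core have been read so far. In a functional assay on HeLa cells (Homo sapiens) for inhibition, read by sulforhodamine B assay (a higher number here means a weaker inhibitor, a lower number a stronger inhibitor), compound 2 `CCOc1ccc(NC2=CC(=O)c3nc4n(c3C2=O)[C@H]2OC[C@@H](O)[C@H]2OC4)cc1` gives 3110 nM. Compound 1 `O=C1C=C(Nc2ccc(Br)cc2)C(=O)c2c1nc1n2[C@H]2OC[C@@H](O)[C@H]2OC1` gives 3830 nM, which lies within the scatter of the compound 2 value. Among the measured compounds shown here, these are the only two numbers in the set, so compound 2 stands level with compound 1. Compound 3 `O=C1C(NC2CC2)=CC(=O)c2c1nc1n2[C@H]2OC[C@@H](O)[C@H]2OC1` gives only a limit, > 16000 nM.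

The next compound, compound 4 `O=C1C=C(Nc2ccc(I)cc2)C(=O)c2c1nc1n2[C@H]2OC[C@@H](O)[C@H]2OC1`, has iodo in place of ethoxy on an aromatic carbon of a six-membered aromatic ring of carbon only, para to a large group: iodo in place of ethoxy on an aromatic carbon. The same difference reads 4-ethoxyphenyl to 4-iodophenyl.

For the measured compounds named here, only one measured step bears on this change. Replacing bromo with ethoxy on an aromatic carbon gave a 1.2-fold lower number from compound 1 to compound 2 (0.09 log units; within the scatter), so the exchange at this place has not yet moved this assay beyond the scatter. This single step is thin evidence, and iodo itself has not been measured in the series. Even so, no shift in either direction beyond the scatter is expected. The estimated step is a 1.1-fold higher number from compound 2 to compound 4 (0.04 log units; within the scatter). For compound 4 the expected value is 3400 nM, with an estimated range of 1700 nM to 7000 nM.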

Compound 4, half-maximal inhibitory concentration: 4070 nM
The estimate for compound 4 lay 1.2-fold (0.08 log units) below the measured number, and the stated range covers the measured number.
By their numbers in this assay, from the lowest: compounds 2, 1 and 4 (each within the scatter of the next). At a limit, above all of these: compound 3.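

Iodo in place of ethoxy gives a 1.3-fold higher number from compound 2 to compound 4 (0.12 log units; within the scatter) in this assay, and iodo in place of bromo gives a 1.1-fold higher number from compound 1 to compound 4 (0.03 log units; within the scatter) on the same aromatic carbon. Where the earlier compounds offered a single exchange at this place, bromo, ethoxy and iodo now form a set of three whose listed steps all lie within the scatter, even though ethoxy, with its 3 heavy atoms and 1 hydrogen-bond acceptor, leaves for iodo, with 1 heavy atom and no acceptor. The compounds shown therefore separate none of these three groups at this place in this assay, and nothing at hand gives a reason for that sameness.

From the compounds shown here alone, whether any group on this aromatic carbon can move the number beyond the scatter stays open, and an amine, a carboxylic acid or a chain longer than ethoxy would test that in a way these three groups cannot. Going by these compounds, compound 3 gives > 16000 nM, which is a limit and not a number, so the size of any gap to it stays open as well.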